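Fluoro to trifluoromethyl on two cores

This account rests on a few compounds, and the source may have more. Where it says the series, first, only, none or still open, it means among the compounds named here.

Of the compounds shown here, three have been tested in an ADME assay on MT4 cells (Homo sapiens) for cytotoxicity, read by MTT assay, with a stated time of 4 days; on this read-out lower numbers stand for higher toxicity in this test and higher numbers for lower toxicity in this test. Compound 1 `CC(=O)Nc1ccc(O)c(C(=O)/C=C/c2cccc(F)c2)c1` and compound 2 `CC(=O)Nc1ccc(O)c(C(=O)/C=C/c2cccc(C(F)(F)F)c2)c1` share one core, and compound 3 `Nc1ccc2oc(-c3ccc(F)cc3)cc(=O)c2c1` has another; the difference between the two cores is not broken down here. In this assay compound 1 gives 30100 nM and compound 2 gives 32100 nM; compound 3 gives 264000 nM, the highest of the three numbers, and its gaps to compound 2 and compound 1 are beyond the scatter.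

The step from compound 1 to compound 2 is trifluoromethyl in place of fluoro on an aromatic carbon, and it made a 1.1-fold higher number from compound 1 to compound 2 (0.03 log units; within the scatter). Compound 4 `Nc1ccc2oc(-c3ccc(C(F)(F)F)cc3)cc(=O)c2c1` arises from compound 3 by trifluoromethyl in place of fluoro on an aromatic carbon. This is the same kind of change as before, not the same: on the core of compound 1 the group sits meta to a large group, on the core of compound 3 it sits para to a large group.

Given that the earlier step was within the scatter, the expected step from compound 3 to compound 4 in this assay is a 1.1-fold lower number from compound 3 to compound 4 (0.02 log units; within the scatter), resting only on a 1.1-fold higher number from compound 1 to compound 2 (0.03 log units; within the scatter) and on the value of compound 3, 264000 nM. The estimate for compound 4 in this assay is 250000 nM, expected to fall between 120000 nM and 450000 nM.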

Compound 4, half-maximal cytotoxic concentration: 273000 nM
Estimate against measurement, compound 4: 1.1-fold (0.04 log units) below; the range from low to high includes it.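

Trifluoromethyl in place of fluoro on an aromatic carbon, here para to a large group, gives a 1.0-fold higher number from compound 3 to compound 4 (0.01 log units; within the scatter) in this assay, so on the core of compound 3 this exchange produces no step beyond the scatter. Within this assay, the change therefore carries from one core to the other with the same null outcome, and the two steps do not differ: the same change on two cores in this assay, a 1.1-fold higher number (0.03 log units; within the scatter) from compound 1 to compound 2 and a 1.0-fold higher number (0.01 log units; within the scatter) from compound 3 to compound 4, 1.0-fold (0.01 log units) apart, within the scatter of two such steps

This holds for two pairs and one read-out only, and two null steps do not establish a rule for the series: they give no reason for the agreement, say nothing about a third core, and do not extend to other assays. They also leave the large gap between the two cores untouched, since compounds on different cores differ in more than one place and that gap cannot be assigned to any single part of the structure.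

Still open, from the compounds shown here alone, is whether a different group in place of fluoro, such as an amine, a carboxylic acid, a methoxy group or a longer chain, would give a step beyond the scatter on either core. Also open, going by these compounds, is whether the exchange to trifluoromethyl stays this small at another place on the aromatic ring of either core.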